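Amide nitrogen substituent and human microsomal clearance

The source may report more compounds than this note shows. Statements on the series, on what has been measured and on what is new or still open speak of the compounds shown alone.

In an in vitro ADME assay on microsomes from liver (Homo sapiens) for pharmacokinetics, read by LC-MS, with a stated time of 10 min, tested at 1 uM (on this read-out higher numbers stand for fast clearance and lower numbers for slow clearance), compound 1 `CN1C[C@H](C(=O)Nc2ccccc2)[C@@H](c2ccc(/C=C/C(=O)Nc3ccccc3N)cc2)C1` gives 7 mL/min/kg, compound 2 `CN1C[C@H](C(=O)Nc2ccc(Br)cc2)[C@@H](c2ccc(/C=C/C(=O)Nc3ccccc3N)cc2)C1` gives 3 mL/min/kg and compound 3 `CN1C[C@H](C(=O)Nc2ccc(F)c(Cl)c2)[C@@H](c2ccc(/C=C/C(=O)Nc3ccccc3N)cc2)C1` gives 15 mL/min/kg. Compound 2 has the lowest number of the three: a 2.3-fold lower number from compound 1 to compound 2 (0.37 log units; beyond the scatter) separates it from its nearest neighbour, and a 5.0-fold higher number from compound 2 to compound 3 (0.70 log units; beyond the scatter) from the furthest. Compound 4 `CN1C[C@H](C(=O)NC2CCCC2)[C@@H](c2ccc(/C=C/C(=O)Nc3ccccc3N)cc2)C1` differs from compound 2 by cyclopentyl in place of 4-bromophenyl on an amide-type nitrogen. Within the data shown here, no measured step exchanges an aromatic ring for a non-aromatic one on the amide-type nitrogen; the steps that bear on it, a 2.3-fold lower number from compound 1 to compound 2 (0.37 log units; beyond the scatter) and a 5.0-fold higher number from compound 2 to compound 3 (0.70 log units; beyond the scatter), are both modest and point upward from compound 2. For compound 4 the expected step is therefore a 2.7-fold higher number from compound 2 to compound 4 (0.43 log units; beyond the scatter), upward and modest. Compound 4 is estimated at 8 mL/min/kg, within a range of 3 mL/min/kg to 20 mL/min/kg.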

Compound 4, clearance: 9 mL/min/kg
For compound 4 the middle estimate is 1.1-fold (0.05 log units) below the measured one; the range from low to high includes it.
By their numbers in this assay, from the lowest: compound 2; then compounds 1, 4 and 3 (each within the scatter of the next, the first and the last beyond it).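

A non-aromatic ring on the amide-type nitrogen still gives a number in the range of the aryl amides in this assay: cyclopentyl in compound 4 cannot be separated from phenyl, with a 1.3-fold higher number from compound 1 to compound 4 (0.11 log units; within the scatter), or from 3-chloro-4-fluorophenyl, with a 1.7-fold lower number from compound 3 to compound 4 (0.22 log units; within the scatter). Only 4-bromophenyl stands apart, with a 3.0-fold higher number from compound 2 to compound 4 (0.48 log units; beyond the scatter), so the low number of compound 2 follows that one group and not aromatic rings in general.

No data here explain these differences. From the compounds shown here alone, whether an amine or a carboxylic acid on the cyclopentyl ring, or a longer chain in its place, keeps the number in this range remains open.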